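The source may hold more compounds than are shown below. What is called first, only, known or untested is meant among the compounds shown, and "the series" means these compounds.

In an assay for inhibition of beta-glucuronidase (Bos taurus), read by spectrophotometry, with a stated time of 30 min (on this read-out lower numbers stand for stronger inhibition and higher numbers for weaker inhibition), compound 3 `CCCCC1NC(=O)NC(C)=C1C(=O)OC` gives 78200 nM, the highest number among the three measured compounds. Compound 1 `COC(=O)C1=C(C)NC(=O)NC1c1ccc(F)c(OC)c1` gives 22100 nM in this assay, and compound 2 `COC(=O)C1=C(C)NC(=O)NC1c1ccc(O)c(Cl)c1` gives 27200 nM; both are beyond the scatter from compound 3, and both carry an aromatic ring where compound 3 carries a butyl chain. Compound 4 `COC(=O)C1=C(C)NC(=O)NC1c1cccs1` has not been measured. It differs from compound 3 by thiophen-2-yl in place of butyl on a saturated ring carbon. Because compound 1 gives 22100 nM and compound 2 gives 27200 nM, a step toward lower numbers is expected for an aromatic ring in this place. Compound 4 is expected to give 28000 nM in this assay, within 12000 nM to 65000 nM. The step this estimate means is a 2.8-fold lower number from compound 3 to compound 4 (0.45 log units; beyond the scatter).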

Compound 4, half-maximal inhibitory concentration: 18200 nM
For compound 4 the middle estimate is 1.5-fold (0.19 log units) above the measured one; measured number inside the range.
By their numbers in this assay, from the lowest: compounds 4, 1 and 2 (each within the scatter of the next); then compound 3.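

Thiophen-2-yl in place of butyl on the saturated ring carbon gives a 4.3-fold lower number from compound 3 to compound 4 (0.63 log units; beyond the scatter) in this assay and so shows the effect of this single change at this position. The lower number is therefore not confined to the substituted aromatic rings of compound 1 and compound 2, since it also appears with a five-membered aromatic ring bearing sulfur. Nothing given here explains this step. The compounds shown leave open whether furan-2-yl or thiophen-3-yl would give a similar number at this carbon, and how a longer chain than butyl would compare.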